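A methyl added to the side chain of compound 3

The source may report more compounds than this note shows. Statements on the series, on what has been measured and on what is new or still open speak of the compounds shown alone.

Compound 3 `COc1cc(C(c2ccc(O)c(OC)c2)[C@H](C)C(C)C)ccc1O` stands lowest of the two numbers shown in a functional assay on HL-60 cells (Homo sapiens) for cytotoxicity, read by WST assay, with a stated time of 48 h (a lower number here means a stronger inhibitor, a higher number a weaker inhibitor), where compound 3 gives 17000 nM. Compound 1 `COc1ccc(C(c2ccc(OC)c(OC)c2)[C@H](C)[C@@H](C)CO)cc1OC` gives 47000 nM in this assay. Compound 2 `COc1ccc(C(c2ccc(OC)c(OC)c2)[C@H](C)[C@H](C)CO)cc1OC` reaches only the limit of the assay, > 100000 nM, in this assay. Among the compounds with values here, the single measured step, an at least 2.1-fold higher number from compound 1 to compound 2 (0.32 log units; beyond the scatter), rests on the fact that compounds 1 and 2 differ only in the configuration as drawn and is bounded by the limit of > 100000 nM in this assay, at which 1 of the 3 values shown sits. Compound 4 `CC[C@H](C(C)C)C(c1ccc(O)c(OC)c1)c1ccc(O)c(OC)c1` differs from compound 3 by methyl in place of hydrogen on a saturated chain carbon, three bonds along the chain from two aromatic carbons. Within the data shown here, no measured step changes a substituent on the saturated chain; the step from compound 1 to compound 2 concerns configuration alone and gives no guide to an added methyl. With nothing pointing either way, the change is expected to give a step of a 1.1-fold lower number from compound 3 to compound 4 (0.05 log units; within the scatter) that stays within the scatter. Compound 4 is therefore estimated at 15000 nM in this assay, with a range from 5000 nM to 50000 nM.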

Compound 4, half-maximal inhibitory concentration: 16000 nM
Compound 4: middle estimate off by 1.1-fold (0.03 log units), on the low side, within the range that was stated.
By their numbers in this assay, from the lowest: compounds 4 and 3 (each within the scatter of the next); then compound 1. At a limit, above all of these: compound 2.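

In this assay, methyl in place of hydrogen on a saturated chain carbon, three bonds along the chain from two aromatic carbons, gives a 1.1-fold lower number from compound 3 to compound 4 (0.03 log units; within the scatter), a step within the scatter. Within the data shown here, this is the first measured step that changes a substituent on the saturated chain, and it shows that this methyl to ethyl change leaves compounds 3 and 4 indistinguishable in this read-out, where the earlier step concerned configuration alone. Nothing available bears on why the step is this small.

On these data alone, whether a propyl, an amine or a carboxylic acid at this carbon would also stay within the scatter of compound 3 remains open. Also open, as far as these compounds go, is whether the same methyl would give so small a step on the core of compound 1.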